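The source may report more compounds than this note shows. Statements on the series, on what has been measured and on what is new or still open speak of the compounds shown alone.

Three related compounds share one core and have been tested in a functional assay (aorta) with Rattus norvegicus as the target; a lower number here means a stronger inhibitor, a higher number a weaker inhibitor. Compound 1 `CC1(C)Oc2ccc(C#N)cc2[C@@H](/N=C(\NC#N)NCc2ccccc2)[C@@H]1O` gives 2400 nM in this assay. Compound 2 `CCC(C)(C)/N=C(\NC#N)N[C@@H]1c2cc(C#N)ccc2OC(C)(C)[C@H]1O` gives 29800 nM in this assay, and compound 3 `CC1(C)Oc2ccc(C#N)cc2[C@@H](n2c(O)nc3ccccc32)[C@@H]1O` gives 41000 nM in this assay. Compound 1 thus stands as the strongest inhibitor of the three, and both of its gaps to the others lie beyond the ordinary scatter of repeated tests.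

Compound 4 `CC1(C)Oc2ccc(C#N)cc2[C@@H](/N=C(\NC#N)Nc2ccc(Cl)c(Cl)c2)[C@@H]1O` has not yet been measured. It differs from compound 1 in one place only: 3,4-dichlorophenyl in place of benzyl on an amine nitrogen. Among the measured compounds shown here, no measured pair in this set shows exactly this kind of exchange, so there is no directly comparable step to lean on. The change keeps the cyanoguanidine part of compound 1 intact, and the group that enters is of similar size to the one that leaves. The expectation is therefore a modest change, if any, with a step from compound 1 to compound 4 of about a 1.6-fold lower number from compound 1 to compound 4 (0.20 log units; within the scatter) expected in this assay. For compound 4 the estimated value in this assay is 1500 nM, with a range of roughly 300 nM to 8000 nM.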

Compound 4, half-maximal inhibitory concentration: 4600 nM
The estimate for compound 4 lay 3.1-fold (0.49 log units) below the measured number, within the range that was stated.
By their numbers in this assay, from the lowest: compounds 1 and 4 (each within the scatter of the next); then compounds 2 and 3 (each within the scatter of the next).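

In this assay, the exchange of benzyl for 3,4-dichlorophenyl on this amine nitrogen gives a 1.9-fold higher number from compound 1 to compound 4 (0.28 log units; within the scatter) and so the two compounds cannot be told apart. Among the compounds shown here, this is the first comparison in the set that alters only this position, and it shows that the cyanoguanidine of compound 1 can carry either an aromatic ring held through one carbon or a dichlorinated ring attached directly to the nitrogen with no clear difference in this test. No measured information is available to explain this result.

The ring's link to the nitrogen and its two chlorine atoms differ together here, so their separate contributions cannot be read. An unsubstituted phenyl group or a longer chain such as 2-phenylethyl on this nitrogen would help to separate them.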